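A Halogen Swap on a Weakly Antiproliferative Series

The compounds below may be only part of what the source reports. "The series", "measured", "known", "first", "only" and "open" are said of these compounds alone.

Three compounds sharing one core were tested in a functional assay on DU-145 cells (Homo sapiens) for antiproliferative activity, read by MTT assay, with a stated time of 48 h; on this read-out higher numbers stand for weaker inhibition and lower numbers for stronger inhibition. Compound 1 `C/C(=C\CC/C(C)=C/CC[C@@H]1[C@@]2(C)CCC(=O)C(C)(C)[C@H]2CC[C@@]1(C)O)CC/C=C(\C)C(=O)OCc1cn(C[C@@H]2O[C@H](n3ccc(=O)[nH]c3=O)[C@H]3OC(C)(C)O[C@H]32)nn1` reaches only a limit of the assay, > 150000 nM, and no number. This is the limit of > 150000 nM in this assay, at which 1 of the 3 values shown sits. Compound 2 `C/C(=C\CC/C(C)=C/CC[C@@H]1[C@@]2(C)CCC(=O)C(C)(C)[C@H]2CC[C@@]1(C)O)CC/C=C(\C)C(=O)OCc1cn(-c2cccc(Cl)c2)nn1` gives 103000 nM, the higher of the two real numbers, while compound 3 `C/C(=C\CC/C(C)=C/CC[C@@H]1[C@@]2(C)CCC(=O)C(C)(C)[C@H]2CC[C@@]1(C)O)CC/C=C(\C)C(=O)OCc1cn(C[C@@H]2O[C@H](n3ccc(=O)[nH]c3=O)C[C@H]2O)nn1` gives 33100 nM, a gap beyond the usual scatter. Compound 4 `C/C(=C\CC/C(C)=C/CC[C@@H]1[C@@]2(C)CCC(=O)C(C)(C)[C@H]2CC[C@@]1(C)O)CC/C=C(\C)C(=O)OCc1cn(-c2ccccc2F)nn1` has not yet been tested; it differs from compound 2 in one place: 2-fluorophenyl in place of 3-chlorophenyl on an aromatic nitrogen. Within the data shown here, no measured pair shows the effect of such a swap, so the expectation rests on compound 2 alone, whose value in this assay is 103000 nM. The expected step is a 1.1-fold higher number from compound 2 to compound 4 (0.03 log units; within the scatter), within the scatter. Compound 4 is expected to give about 110000 nM, with a likely range from 45000 nM to 250000 nM.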

Compound 4, half-maximal inhibitory concentration: > 150000 nM
Compound 4 gave a limit, no number; the forecaster's own chance of this, stated with the estimate: 35%; middle value at least 1.3-fold (0.13 log units) from the limit.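

Among these compounds, putting 2-fluorophenyl in place of 3-chlorophenyl on the aromatic nitrogen gives the first comparison here of compounds differing in one place, an at least 1.4-fold higher number from compound 2 to compound 4 (0.16 log units; that floor lies within the scatter). The result for compound 4 is a limit of the assay, not a number. The step is therefore only a floor, so its true size is unknown, although the swap clearly brought no stronger inhibition: the limit of > 150000 nM in this assay, at which 2 of the 4 values shown sit.

This swap changes both the halogen and its place on the phenyl ring, and the compounds shown cannot separate the two. Going by these compounds, whether an amine or a carboxylic acid on that phenyl ring would lower the number also stays open.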